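A few compounds are considered here, and "the series" means these few. Any claim that something is new, unique, unknown or untested is made for them only; others in the source may bear on it.

Measured so far in a functional assay on PC-3 cells (Homo sapiens) for antiproliferative activity, read by MTT assay, with a stated time of 24 h; on this read-out higher numbers stand for weaker inhibition and lower numbers for stronger inhibition:

- compound 1 `CCn1c(C(=O)N[C@@H](CC(=O)OC)C(=O)OC)ccc1C(CC)(CC)c1ccc(OCS(=O)(=O)c2ccccc2)c(C)c1` gives 6490 nM
- compound 2 `CCN(CC)CCNC(=O)c1ccc(C(CC)(CC)c2ccc(OCS(=O)(=O)c3ccccc3)c(C)c2)n1CC` gives 7130 nM

Only compound 1 is available for comparison with compound 2, and their two values lie within the usual scatter of repeated measurements, so the data cannot rank one above the other.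

Compound 3 `CCN(CC)CCNC(=O)c1ccc(C(CC)(CC)c2ccc(OCS(C)(=O)=O)c(C)c2)n1CC` differs from compound 2 in a single place: methyl in place of phenyl on a sulfonyl sulfur. Put simply, this is methyl in place of phenyl on a sulfonyl sulfur, turning phenylsulfonyl into methylsulfonyl.

Going by the values given here, the only measured step is a 1.1-fold higher number from compound 1 to compound 2 (0.04 log units; within the scatter). It replaces the group on an amide-type nitrogen and leaves the sulfonyl end untouched, so it bears on the new change only indirectly. It shows one replacement elsewhere in the molecule that stayed within the scatter. Among the compounds with values here, no measured step involves the sulfonyl sulfur, so the data offer no direction, and no shift beyond the scatter is expected in this assay, though with wide uncertainty. The expected step is a 1.1-fold higher number from compound 2 to compound 3 (0.05 log units; within the scatter). Compound 3 is estimated at 8000 nM, with an expected range from 2500 nM to 25000 nM.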

Compound 3, half-maximal inhibitory concentration: 46700 nM
For compound 3 the middle estimate is 5.8-fold (0.77 log units) below the measured one; the whole stated range lies below it.
By their numbers in this assay, from the lowest: compounds 1 and 2 (each within the scatter of the next); then compound 3.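

In this assay, the sulfonyl end of the molecule proves sensitive: methyl in place of phenyl on the sulfonyl sulfur gives a 6.5-fold higher number from compound 2 to compound 3 (0.82 log units; beyond the scatter), and this step lies beyond the scatter. The earlier step, a 1.1-fold higher number from compound 1 to compound 2 (0.04 log units; within the scatter), changed the group on an amide-type nitrogen and stayed within the scatter, so this is the first change among the compounds shown that separates two values, and it links the loss of the phenyl ring to weaker inhibition of PC-3 cell growth. Nothing available explains this shift, so the result records what happened at this position but not how it comes about.

With only phenyl and methyl compared on the sulfonyl sulfur, the compounds shown cannot tell whether the aromatic ring itself matters or whether a larger group of any kind would serve as well, a question that cyclohexyl, ethyl or a substituted phenyl such as 4-fluorophenyl at this place could help to settle. As far as these compounds go, it also stays open whether the same step would appear with 1,2-bis(methoxycarbonyl)ethyl rather than 2-(diethylamino)ethyl on the amide-type nitrogen.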